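Removing One Methyl From the Amine Nitrogen on Two Cores

A few compounds are considered here, and "the series" means these few. Any claim that something is new, unique, unknown or untested is made for them only; others in the source may bear on it.

Measured so far in a functional assay on LS174T cells (Homo sapiens) for antiproliferative activity; on this read-out higher numbers stand for weaker inhibition and lower numbers for stronger inhibition:
- Compound 1 `CN(C)c1ccc(/C=C/c2c(Cl)cccc2Cl)cc1` gives 214 nM.
- Compound 2 `CNc1ccc(/C=C/c2c(Cl)cccc2Cl)cc1` gives 50.1 nM.
- Compound 3 `CN(C)c1ncc(/C=C/c2c(F)cccc2F)cn1` gives > 200 nM, which is a limit of this assay and not a number.

Compound 1 and compound 2 share one core and differ in one place: hydrogen in place of methyl on a nitrogen on an aromatic ring. That change brought a 4.3-fold lower number from compound 1 to compound 2 (0.63 log units; beyond the scatter).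

Compound 4 `CNc1ncc(/C=C/c2c(F)cccc2F)cn1` is not yet measured. It stands to compound 3 as compound 2 stands to compound 1: hydrogen in place of methyl on a nitrogen on an aromatic ring. The surroundings of the changed nitrogen read the same in both pairs, so this is the same change, made on a second core. How the core of compound 3 differs from the core of compound 1 is not broken down here.

Compound 3 sits at the limit of > 200 nM in this assay, at which 1 of the 3 values shown sits, so its real value is not known, only that it lies at or beyond that limit. That makes a forecast for compound 4 uncertain. If the change behaved as it did on the first core, compound 4 would be expected to show an at least 1.3-fold lower number from compound 3 to compound 4 (0.12 log units; that floor lies within the scatter), resting on the step seen in a 4.3-fold lower number from compound 1 to compound 2 (0.63 log units; beyond the scatter), but the unknown starting point of compound 3 widens the range. Compound 4 is therefore estimated at 150 nM, within 40 nM to 600 nM in this assay.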

Compound 4, half-maximal inhibitory concentration: > 200 nM
Compound 4: no number, only a limit; the forecaster's own chance of this, stated with the estimate: 45%; middle value at least 1.3-fold (0.12 log units) from the limit.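

In this assay, compound 3 gives > 200 nM, which is a limit of the assay and not a number. Compound 4 gives > 200 nM, also a limit and not a number, so no step can be read between compound 3 and compound 4. The compounds shown leave open whether hydrogen in place of methyl lowers the number on this second core, as it did on the first.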